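The source may report more compounds than this note shows. Statements on the series, on what has been measured and on what is new or still open speak of the compounds shown alone.

Of the compounds shown here, three have so far been measured in a functional assay on Umbilical vein for antagonist activity at B1 bradykinin receptor (Homo sapiens), using Schild analysis, with a stated time of 30 min; a lower number here means a less potent compound, a higher number a more potent compound, by a factor of ten per unit of this negative logarithm. Compound 1 `CCN(CC)CCN1CCN(C(=O)COCCN(C)S(=O)(=O)c2c(C)cc(OC)cc2C)CC1` gives 7.8. Compound 3 `COc1cc(C)c(S(=O)(=O)N(C)CCOCC(=O)N2CCC(N3CCN(C(C)C)CC3)CC2)c(C)c1` gives 8.5. Compound 2 `Cc1c(Cl)ccc(S(=O)(=O)N(C)CCOCC(=O)N(C)Cc2ccc(C3=NCCN3)cc2)c1Cl` gives 9.1, the highest of the three: the nearest to it is compound 3, and that gap is beyond the scatter, while compound 1 lies furthest away, also beyond the scatter. Compound 2 is thus the most potent of the three measured compounds in this assay.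

Compound 4 `CN(Cc1ccc(C2=NCCN2)cc1)C(=O)COCCN(C)S(=O)(=O)c1c(F)cccc1F` has not yet been measured in this assay. It differs from compound 2 in one place: 2,6-difluorophenyl in place of 2,4-dichloro-3-methylphenyl on a sulfonyl sulfur. Among the measured compounds shown here, no pair of measured compounds shows this particular change, so no measured step tells how large its effect is, and the three measured values are all that any expectation can rest on. Among them compound 2, with 9.1, is the only one carrying the 2,4-dichloro-3-methylphenyl group, and the smaller 2,6-difluorophenyl group has no measured counterpart at all.

The expectation for compound 4 in this assay is a value near 8.3, with a likely range from 7.5 to 9.1. The expected step from compound 2 to compound 4 is a number 0.80 log units lower from compound 2 to compound 4 (beyond the scatter), a fall somewhat beyond the scatter, though the uncertainty is wide.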

Compound 4, negative logarithm of the antagonist equilibrium constant: 7.6
Compound 4: the middle estimate sits 0.70 log units above what was measured; low and high end bracket the measured number.
By their numbers in this assay, from the lowest: compounds 4 and 1 (each within the scatter of the next); then compound 3; then compound 2.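

In this assay, among the compounds shown here, this is the first measured change at a single position, and it shows that the aryl group on the sulfonyl sulfur strongly affects potency: 2,6-difluorophenyl in place of 2,4-dichloro-3-methylphenyl gives a number 1.50 log units lower from compound 2 to compound 4 (beyond the scatter), with the rest of the molecule unchanged. The counts do little to separate the two groups, since each is one six-membered aromatic ring of carbon only, with no hydrogen-bond donors, no hydrogen-bond acceptors and no net charge, so a large step can accompany a swap that leaves these features the same. No measurement is available that explains the size of this fall.

This single pair changes the halogen, the pattern of groups on the ring and the methyl group all at once, so it remains open which of these differences accounts for the step. Plain phenyl, 2,6-dichlorophenyl or a pyridine ring on the sulfonyl sulfur, each with the rest of compound 2 kept the same, would be ways to pull these differences apart.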